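One Group Exchanged at a Ring Carbon: Compound 1 to 4

The source may hold more compounds than are shown below. What is called first, only, known or untested is meant among the compounds shown, and "the series" means these compounds.

Compound 1 `CN(C)/C(=N\C#N)C1=CC(C)(C)Oc2ccc([N+](=O)[O-])cc21` has no single number: in a functional assay on the whole organism (aorta) with Rattus norvegicus as the target (a lower number here means a smaller maximal response, a higher number a larger maximal response), compound 1 is entered as "nt" (no result reported). Compound 3 `CN(C)/C(=N\C#N)C1=CC(C)(C)Oc2ccc(Br)cc21` likewise has no reported result: in this assay compound 3 is entered as "nt" (no result reported). Only compound 2 `CN(C)/C(=N\C#N)C1=CC(C)(C)Oc2ccc(C#N)cc21` carries a number: in this assay compound 2 gives 73.7%. Compound 4 `CN(C)C(=S)C1=CC(C)(C)Oc2ccc([N+](=O)[O-])cc21` has not yet been measured. It arises from compound 1 by a single change: a group of 5 heavy atoms (3 carbon, 1 nitrogen, 1 sulfur; no ring) in place of a group of 7 heavy atoms (4 carbon, 3 nitrogen; no ring), on a double-bonded ring carbon. Among the compounds with values here, no measured pair differs in just one place, so nothing here shows how such a swap plays out; the direction and size of the step in this assay from compound 1 to compound 4 remain open, and a move beyond the usual scatter can be neither promised nor excluded. Within the data shown here, the only anchor is compound 2 at 73.7%. On that basis compound 4 is expected to give around 70%, within a wide range from 35% to 100%.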

Compound 4, intrinsic activity: the largest response reached, in percent of the reference agonist's: 71.5%
The estimate for compound 4 lay 1.5 percentage points below the measured number, and the stated range covers the measured number.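

Within the data shown here, compound 1 has no single number in this assay, and no step from it to compound 4 can be read. The compounds shown leave open how exchanging this group at the ring carbon changes the maximal response. No evidence is available to explain the result for compound 4.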